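Fluoro for Iodo: Expected Outcome for Compound 4

A few compounds are considered here, and "the series" means these few. Any claim that something is new, unique, unknown or untested is made for them only; others in the source may bear on it.

Compound 1 `CC(=NNC(=S)Nc1cccc(I)c1)c1ccccn1` gives 61 nM in a functional assay on T98G cells (Homo sapiens) for cytotoxicity, read by MTT assay, with a stated time of 48 h; a lower number here means a stronger inhibitor, a higher number a weaker inhibitor. Compound 2 `C/C(=N\NC(=S)Nc1cccc(I)c1)c1ccccn1` gives 61 nM and compound 3 `C/C(=N/NC(=S)Nc1cccc(I)c1)c1ccccn1` gives 61 nM, so the three stand level: no change at the digits printed from compound 1 to compound 2 (within the scatter), no change at the digits printed from compound 1 to compound 3 (within the scatter) and no change at the digits printed from compound 2 to compound 3 (within the scatter) each stay within the scatter, and each of those steps concerns only the drawn configuration (the fact that one of compounds 1 and 2 is drawn with a defined configuration and the other without, at the place where they differ, (the fact that one of compounds 1 and 3 is drawn with a defined configuration and the other without, at the place where they differ), (the fact that compounds 2 and 3 differ only in the configuration as drawn)). Compound 4 `CC(=NNC(=S)Nc1cccc(F)c1)c1ccccn1` carries fluoro in place of iodo on an aromatic carbon. Among the compounds with values here, no measured step alters this group, so none bears directly on the move; the measured steps only show that configuration as drawn leaves the value unmoved. The expectation for compound 4 therefore rests on compound 1 alone, and a modest weakening is expected, a 3.3-fold higher number from compound 1 to compound 4 (0.52 log units; beyond the scatter). Compound 4 is estimated at 200 nM, between 50 nM and 800 nM.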

Compound 4, half-maximal inhibitory concentration: 12 nM
Estimate against measurement, compound 4: 17-fold (1.22 log units) above; measured number outside the range, below it.
By their numbers in this assay, from the lowest: compound 4; then compounds 1, 2 and 3 (each within the scatter of the next).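

This position on the aromatic carbon responds to its substituent, which the steps among compounds 1, 2 and 3, all at the drawn configuration, could not show: in this assay fluoro in place of iodo gives a 5.1-fold lower number from compound 1 to compound 4 (0.71 log units; beyond the scatter). Iodo is therefore not required here for a low number. Nothing available on this series bears on the reason for this step.

Still open, from the compounds shown here alone, is where chloro, bromo, methoxy or an amine at this place would fall. One pair of halogens sets no trend, and whether the step holds on other cell lines is also unsettled.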